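Propyl, Isobutyl and Allyl Carbamates of a Selenocyanate

The source may report more compounds than this note shows. Statements on the series, on what has been measured and on what is new or still open speak of the compounds shown alone.

Within the data shown here, compound 2 `CC(C)COC(=O)Nc1ccc([Se]C#N)cc1` holds the highest of the two numbers so far recorded in an ADME assay on 184B5 cells (Homo sapiens) for cytotoxicity, read by MTT assay, with a stated time of 72 h (a higher number here means a weaker inhibitor of growth, a lower number a stronger inhibitor of growth), giving 21600 nM. Among the measured compounds shown here, its nearest neighbour is compound 1 `CCCOC(=O)Nc1ccc([Se]C#N)cc1`, which in this assay gives 9100 nM; the single measured step is a 2.4-fold higher number from compound 1 to compound 2 (0.38 log units; beyond the scatter). Compound 3 `C=CCOC(=O)Nc1ccc([Se]C#N)cc1` has not yet been measured in this assay. It differs from compound 2 in one place: vinyl in place of isopropyl on a saturated chain carbon bound to an oxygen next to a carbonyl group. For the measured compounds named here, only the step from compound 1 to compound 2 bears on this change, and it runs the other way, since the branching that step introduced on the chain is removed again in compound 3, leaving an unbranched chain like that of compound 1. A step back of roughly that size is therefore expected, a 2.0-fold lower number from compound 2 to compound 3 (0.29 log units; within the scatter). Compound 3 is thus estimated to give 11000 nM, within a range of 4000 nM to 30000 nM.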

Compound 3, concentration for total growth inhibition: 9800 nM
For compound 3 the middle estimate is 1.1-fold (0.05 log units) above the measured one; measured number inside the range.
By their numbers in this assay, from the lowest: compounds 1 and 3 (each within the scatter of the next); then compound 2.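

In this assay, vinyl in place of isopropyl on a saturated chain carbon bound to an oxygen next to a carbonyl group gives a 2.2-fold lower number from compound 2 to compound 3 (0.34 log units; beyond the scatter), so going from isobutyl to allyl moves the number by a step beyond the scatter. Vinyl in place of ethyl at the same place gives a 1.1-fold higher number from compound 1 to compound 3 (0.03 log units; within the scatter), which does not separate the allyl chain from the propyl chain, and among these three compounds only the isobutyl chain of compound 2 stands apart. No measurement in hand accounts for this difference.

The compounds shown leave open whether a longer chain, or a chain ending in an amine, would stay with compound 1 and compound 3 or move away from them. With isobutyl as the only branched chain, they also leave open whether another branched chain would stand apart in the same way.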